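This account rests on a few compounds, and the source may have more. Where it says the series, first, only, none or still open, it means among the compounds named here.

Of the compounds shown here, three built on one shared core have been read in a functional assay on MCF7 cells (Homo sapiens) for inhibition, read by MTT assay, with a stated time of 48 h; on this read-out lower numbers stand for stronger inhibition and higher numbers for weaker inhibition. Compound 1 `CCOC(=O)C1=C(N/C=N/c2cccnc2Cl)Nc2[nH]nc(C)c2C1c1ccc(N(C)C)cc1` gives 4180 nM. Compound 2 `CCOC(=O)C1=C(N/N=C(/Cl)c2ccc([N+](=O)[O-])cc2)Nc2[nH]nc(C)c2C1c1ccc(N(C)C)cc1` gives 52700 nM. Compound 3 `CCOC(=O)C1=C(N/N=C(/Br)c2ccccc2)Nc2[nH]nc(C)c2C1c1ccc(N(C)C)cc1` gives 78400 nM. Compound 3 cannot be told apart from compound 2, with a 1.5-fold higher number from compound 2 to compound 3 (0.17 log units; within the scatter), while both lie well away from compound 1, with a 19-fold higher number from compound 1 to compound 3 (1.27 log units; beyond the scatter) and a 13-fold higher number from compound 1 to compound 2 (1.10 log units; beyond the scatter).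

Compound 4 `CCOC(=O)C1=C(N/N=C(/C(=O)Br)c2ccc(Cl)cc2)Nc2[nH]nc(C)c2C1c1ccc(N(C)C)cc1` has not yet been measured. The change leading to it from compound 3 is a group of 12 heavy atoms (8 carbon, 1 nitrogen, 1 oxygen, 1 chlorine, 1 bromine; one six-membered aromatic ring of carbon only) in place of a group of 9 heavy atoms (7 carbon, 1 nitrogen, 1 bromine; one six-membered aromatic ring of carbon only), on an amine nitrogen. Compound 4 keeps the six-membered aromatic ring of carbon only, as compound 2 and compound 3 do, and only compound 1 has the ring with a hetero atom. The two large steps both start from compound 1 and both involve that ring, so they bear less on this change. The closer guide is the step between the two compounds with carbon-only rings, which differ in group size much as compound 3 and compound 4 do, and that step stays within the scatter. No step beyond the scatter is therefore expected in this assay. The estimate is a 1.6-fold lower number from compound 3 to compound 4 (0.20 log units; within the scatter). For compound 4 the expected value is 50000 nM, with an estimated range of 15000 nM to 130000 nM.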

Compound 4, half-maximal inhibitory concentration: 46300 nM
Beside the measured number, compound 4's estimate is 1.1-fold (0.03 log units) above it; the range from low to high includes it.
By their numbers in this assay, from the lowest: compound 1; then compounds 4, 2 and 3 (each within the scatter of the next).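

In this assay, the group on the amine nitrogen can go from the 9 heavy atoms of compound 3 to the 12 heavy atoms of compound 4, with 2 double bonds outside aromatic rings and 2 hydrogen-bond acceptors in place of 1 of each, and the read-out still shows only a 1.7-fold lower number from compound 3 to compound 4 (0.23 log units; within the scatter). Compound 4 also matches compound 2 despite a different atom make-up at the same group size, with a 1.1-fold lower number from compound 2 to compound 4 (0.06 log units; within the scatter), yet it stays well apart from the first compound, with an 11-fold higher number from compound 1 to compound 4 (1.04 log units; beyond the scatter), so all three compounds with a carbon-only aromatic ring now stand clear of compound 1. Nothing measured here accounts for these readings.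

The compounds shown leave open whether the gap to compound 1 follows from its ring with a hetero atom or from the rest of its group, as the two features never vary separately. They also leave open whether an amine or a carboxylic acid in place of the bromine would move the number beyond the scatter.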